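An Ethoxy Group Added to the Phenyl of Compound 2

The source may hold more compounds than are shown below. What is called first, only, known or untested is meant among the compounds shown, and "the series" means these compounds.

Measured so far:
compound 1 `C=C(Br)C(=O)Nc1cccc(-c2cn3nc(Cc4ccccc4)sc3n2)c1`: 3000 nM
compound 2 `C=C(Br)C(=O)Nc1cccc(-c2cn3nc(-c4ccccc4)sc3n2)c1`: 900 nM

In a functional assay on FM3A cells (Mus musculus) for inhibition, read by cell counting, with a stated time of 2 days (on this read-out higher numbers stand for weaker inhibition and lower numbers for stronger inhibition), compound 2 gives 900 nM, the lowest of the two numbers. Among the measured compounds shown here, its only neighbour, compound 1, gives 3000 nM, and the single measured step, a 3.3-fold lower number from compound 1 to compound 2 (0.52 log units; beyond the scatter), lies beyond the scatter. Compound 3 `C=C(Br)C(=O)Nc1cccc(-c2cn3nc(-c4ccc(OCC)cc4)sc3n2)c1` keeps the whole of compound 2 and changes one place: ethoxy in place of hydrogen on an aromatic carbon. For the measured compounds named here, no measured step speaks to this change. Going by the values given here, the one step available, a 3.3-fold lower number from compound 1 to compound 2 (0.52 log units; beyond the scatter), concerns the phenyl itself and not a group placed on it, so it offers no direct guide to what an ethoxy on that phenyl does. With nothing pointing in either direction, compound 3 is expected to sit close to compound 2, with a step of about a 1.3-fold lower number from compound 2 to compound 3 (0.11 log units; within the scatter) that need not exceed the scatter. The estimate for compound 3 in this assay is therefore 700 nM, within a range of 250 nM to 2000 nM.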

Compound 3, half-maximal inhibitory concentration: 1100 nM
The estimate for compound 3 lay 1.6-fold (0.20 log units) below the measured number, and the stated range covers the measured number.
By their numbers in this assay, from the lowest: compounds 2 and 3 (each within the scatter of the next); then compound 1.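

In this assay the aromatic carbon on the phenyl of compound 2 accepts an ethoxy in place of hydrogen, and the step of a 1.2-fold higher number from compound 2 to compound 3 (0.09 log units; within the scatter) stays within the scatter, so the phenyl to 4-ethoxyphenyl change leaves the number effectively unmoved at this position. The advantage over the benzyl of compound 1 also persists with the ethoxy in place, as a 2.7-fold lower number from compound 1 to compound 3 (0.44 log units; beyond the scatter) still lies beyond the scatter. No evidence is available to explain why this change has so little effect on the number.

The compounds shown leave open whether a methoxy, an amine, a carboxylic acid or a longer chain at this same carbon would also leave the number unmoved. They also leave open whether an ethoxy on another carbon of the phenyl would behave in the same way.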